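The source may hold more compounds than are shown below. What is called first, only, known or untested is meant among the compounds shown, and "the series" means these compounds.

- Compound 1 `CCCCCC(=O)Nc1nc(N)nc2c1ncn2[C@H]1CO[C@@H](CO)O1`: > 100000 nM (a limit)
- Compound 2 `CCCCCCCCCC(=O)Nc1nc(N)nc2c1ncn2[C@H]1CO[C@@H](CO)O1`: > 100000 nM (a limit)
- Compound 3 `CCCCCCCCCCCCCC(=O)Nc1nc(N)nc2c1ncn2[C@H]1CO[C@@H](CO)O1`: > 100000 nM (a limit)

In an ADME assay on PBMC cells (Homo sapiens) for cytotoxicity (on this read-out higher numbers stand for lower toxicity in this test and lower numbers for higher toxicity in this test), compound 3 stands at > 100000 nM, which is a limit and not a number. The same holds across the series: the limit of > 100000 nM in this assay, at which 3 of the 3 values shown sit.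

Compound 4 `CCCCCCCC/C=C\CCCCCCCC(=O)Nc1nc(N)nc2c1ncn2[C@H]1CO[C@@H](CO)O1` differs from compound 3 by this change: dec-1-en-1-yl in place of hexyl on a saturated chain carbon, seven bonds along the chain from a carbonyl carbon.

For the measured compounds named here, three measured steps bear on it: a step that the two limits leave unreadable from compound 1 to compound 2; a step that the two limits leave unreadable from compound 1 to compound 3; a step that the two limits leave unreadable from compound 2 to compound 3. Going by the values given here, none gives a size, and no measured compound carries dec-1-en-1-yl. No step beyond the scatter is therefore expected in this assay, and a further limit is the likeliest report. The expected step is a number no higher from compound 3 to compound 4 (the limit leaves the size open). Compound 4 is estimated at 100000 nM, with an expected range of 50000 nM to 200000 nM.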

Compound 4, half-maximal cytotoxic concentration: 76000 nM
Compound 4: the middle estimate sits 1.3-fold (0.12 log units) above what was measured; the measured number falls inside the stated range.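

In this assay, compound 4 is the only one shown that gives a number and not a limit, with dec-1-en-1-yl in place of hexyl on a saturated chain carbon, seven bonds along the chain from a carbonyl carbon: the limit of > 100000 nM in this assay, at which 3 of the 4 values shown sit.

The result reads as an at least 1.3-fold lower number from compound 3 to compound 4 (0.11 log units; that floor lies within the scatter), as an at least 1.3-fold lower number from compound 2 to compound 4 (0.11 log units; that floor lies within the scatter) and as an at least 1.3-fold lower number from compound 1 to compound 4 (0.11 log units; that floor lies within the scatter). The steps among the three earlier compounds cannot be read.

From the compounds shown here alone, the true size of these steps stays open. So does the outcome with decyl in place of dec-1-en-1-yl, which would separate the double bond from chain length.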